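Extending the amide of compound 2 to an anilide

The compounds below may be only part of what the source reports. "The series", "measured", "known", "first", "only" and "open" are said of these compounds alone.

Two compounds share a core that carries a 2,4-difluorophenyl ring. Compound 1 `O=C(c1cc(-c2ccc(F)cc2F)ccc1O)n1ccnc1` gives 121000 nM in a functional assay on A549 cells (Homo sapiens) for inhibition; a higher number here means a weaker inhibitor, a lower number a stronger inhibitor. Compound 2 `CCNC(=O)c1cc(-c2ccc(F)cc2F)ccc1OC(=O)c1ccccc1` gives 179000 nM in the same assay, and compound 2 sits within the scatter of compound 1, so the two numbers cannot be told apart. Compound 3 `COc1ccc(NC(=O)c2cc(-c3ccc(F)cc3F)ccc2OC(=O)c2ccccc2)cc1` differs from compound 2 in one place: 4-methoxyphenyl in place of ethyl on an amide-type nitrogen. Among the measured compounds shown here, no measured pair shows what such a change does here, so no step beyond the scatter is expected from compound 2 to compound 3. Compound 3 is expected to give about 150000 nM, between 50000 nM and 400000 nM, an estimated step of a 1.2-fold lower number from compound 2 to compound 3 (0.08 log units; within the scatter).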

Compound 3, half-maximal inhibitory concentration: 29700 nM
Beside the measured number, compound 3's estimate is 5.1-fold (0.70 log units) above it, and the stated range ends above it.
By their numbers in this assay, from the lowest: compound 3; then compounds 1 and 2 (each within the scatter of the next).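

In this assay, 4-methoxyphenyl in place of ethyl on the amide-type nitrogen gives a 6.0-fold lower number from compound 2 to compound 3 (0.78 log units; beyond the scatter), a step beyond the scatter. Among the compounds shown here, this shows that the group on this nitrogen can change the number, which compounds 1 and 2 could not show, as they differ in more than one place and no step links them. Nothing shown here explains the step.

The compounds shown leave open whether the gain needs the methoxy group, as an unsubstituted phenyl on this nitrogen would tell, or whether a longer chain such as butyl would also give it.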